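The compounds below may be only part of what the source reports. "The series", "measured", "known", "first", "only" and "open" are said of these compounds alone.

Compound 3, whose structure is `COc1ccc(-n2ccc(=O)c(C(=O)Nc3ccc(Oc4ccnc5c4ccn5C)c(F)c3)n2)cc1`, is the weakest point of reference in this set: in a functional assay on MCF7 cells (Homo sapiens) for cytotoxicity, read by MTT assay, with a stated time of 72 h (a higher number here means a weaker inhibitor, a lower number a stronger inhibitor), compound 3 reaches only the limit of the assay, reported as > 60000 nM, so no number stands behind it. Its close relative compound 1, with the structure `COc1ccc(-n2ccc(=O)c(C(=O)Nc3ccc(Oc4ccnc5[nH]ccc45)c(F)c3)n2)cc1`, gives 55400 nM in this assay. Going by the values given here, the one measured step that joins these two, an at least 1.0-fold higher number from compound 1 to compound 3 (0.03 log units; that floor lies within the scatter), is the sole step on record, and it is anchored at the limit of > 60000 nM in this assay, at which 1 of the 3 values shown sits.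

The change now in view is 4-bromo-2-fluorophenyl in place of 4-methoxyphenyl on an aromatic nitrogen, giving compound 4 with the structure `Cn1ccc2c(Oc3ccc(NC(=O)c4nn(-c5ccc(Br)cc5F)ccc4=O)cc3F)ccnc21`. Among the compounds with values here, no measured step describes this exchange in the shared core. Within the data shown here, the only compound that already carries the 4-bromo-2-fluorophenyl group is compound 2, whose structure is `Cn1ccc2c(Oc3ccc(NC(=O)c4nn(-c5ccc(Br)cc5F)ccc4=O)cc3)ccnc21`; in this assay compound 2 gives 19800 nM, though compound 2 and compound 4 also differ elsewhere, so their two values alone say what they show and nothing more. With compound 3 sitting at a limit, any step from it can only be estimated loosely; it is expected to run toward a lower number, as an at least 2.0-fold lower number from compound 3 to compound 4 (0.30 log units; that floor lies within the scatter). Compound 4 is therefore estimated at 30000 nM, within a range from 10000 nM to 90000 nM.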

Compound 4, half-maximal inhibitory concentration: 14100 nM
Estimate against measurement, compound 4: 2.1-fold (0.33 log units) above; low and high end bracket the measured number.
By their numbers in this assay, from the lowest: compounds 4 and 2 (each within the scatter of the next); then compound 1. At a limit, above all of these: compound 3.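

Going by these compounds alone, exchanging 4-methoxyphenyl for 4-bromo-2-fluorophenyl on the aromatic nitrogen gives, in this assay, the first step in this set that stands clear of the scatter, an at least 4.2-fold lower number from compound 3 to compound 4 (0.62 log units; beyond the scatter), so this position on the ring with two nitrogens can respond to the group placed there. The size of that step is only a floor, and compound 3 is a limit of the assay rather than a number: the limit of > 60000 nM in this assay, at which 1 of the 4 values shown sits. Fluoro in place of hydrogen on an aromatic carbon amounts to a 1.4-fold lower number from compound 2 to compound 4 (0.15 log units; within the scatter) and so cannot be told from repeat scatter, which leaves the aryl exchange as the only step here beyond it.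

A phenyl ring carrying bromo alone or fluoro alone, or an amine or a carboxylic acid, stands outside the compounds shown, so it stays open which part of the new group goes with the lower number. Equally open, as far as these compounds go, is whether the step holds with hydrogen in place of the methyl on the aromatic nitrogen of the shared core.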